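The source may hold more compounds than are shown below. What is called first, only, known or untested is meant among the compounds shown, and "the series" means these compounds.

Compound 1 `CCn1c(/C=C2/C(=O)Nc3ccc(F)cc32)nc2ccccc21` — > 50000 nM
Compound 2 `Cn1c(/C=C2/C(=O)Nc3ccc(F)cc32)nc2ccccc21` — 29600 nM

In a functional assay on 4T1 cells (Homo sapiens) for cytotoxicity, read by MTT assay, with a stated time of 48 h (a higher number here means a weaker inhibitor, a lower number a stronger inhibitor), compound 1 reaches only the limit (the limit of > 50000 nM in this assay, at which 1 of the 2 values shown sits), so its value is a limit rather than a number. Compound 2 gives 29600 nM. Within the data shown here, the single measured step, an at least 1.6-fold lower number from compound 1 to compound 2 (0.22 log units; that floor lies within the scatter), alters the chain on the aromatic nitrogen and not the ring substituent, so it does not bear on the change to compound 3 `CCn1c(/C=C2/C(=O)Nc3ccc([N+](=O)[O-])cc32)nc2ccccc21`, which is nitro in place of fluoro on an aromatic carbon. Among the measured compounds shown here, no measured step covers this exchange, and no movement beyond the scatter is expected. Compound 3 is therefore estimated at 45000 nM, within 15000 nM to 100000 nM. The expected step of an at least 1.1-fold lower number from compound 1 to compound 3 (0.04 log units; that floor lies within the scatter) is thus no change beyond the scatter.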

Compound 3, half-maximal inhibitory concentration: > 50000 nM
Compound 3 ended at the assay's limit; the forecaster's own chance of this, stated with the estimate: 50%; middle value at least 1.1-fold (0.04 log units) away from the limit.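

Compound 1 and compound 3 both stand at a limit of this assay rather than at a number, so the step between them cannot be read: the limit of > 50000 nM in this assay, at which 2 of the 3 values shown sit. On these data alone, whether nitro in place of fluoro changes the value at all stays open.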